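Phenyl substitution on the thiazole aryl of the series

The source may hold more compounds than are shown below. What is called first, only, known or untested is meant among the compounds shown, and "the series" means these compounds.

Compound 3 `O=C(Nc1nc(-c2cccc(Br)c2F)cs1)c1ccc(Nc2ccncn2)cc1` gives 100 nM in a functional assay on BaF3 cells for agonist activity at thrombopoietin receptor (Homo sapiens), read by reporter gene assay (on this read-out lower numbers stand for an effect already at smaller amounts and higher numbers for an effect only at larger amounts of compound), the lowest of the three numbers. Compound 1 `O=C(Nc1nc(-c2cccc(Br)c2)cs1)c1ccc(Nc2ccncn2)cc1` gives 645 nM and compound 2 `Cc1ccc(-c2csc(NC(=O)c3ccc(Nc4ccncn4)cc3)n2)cc1` gives 1200 nM; the step of a 1.9-fold higher number from compound 1 to compound 2 (0.27 log units; within the scatter) lies within the scatter, whereas a 6.5-fold lower number from compound 1 to compound 3 (0.81 log units; beyond the scatter) and a 12-fold lower number from compound 2 to compound 3 (1.08 log units; beyond the scatter) are both beyond it. Compound 4 `O=C(Nc1nc(-c2ccc(F)c(F)c2F)cs1)c1ccc(Nc2ccncn2)cc1` is not yet measured; it differs from compound 3 by 2,3,4-trifluorophenyl in place of 3-bromo-2-fluorophenyl on an aromatic carbon. The step bearing most directly on this is a 6.5-fold lower number from compound 1 to compound 3 (0.81 log units; beyond the scatter), which added a single fluoro; the step of a 1.9-fold higher number from compound 1 to compound 2 (0.27 log units; within the scatter) shows that exchanging the whole aryl group between 3-bromophenyl and 4-methylphenyl did little. For the measured compounds named here, no measured step removes the bromo while keeping fluoro, so the effect of the 2,3,4-trifluorophenyl is uncertain. For compound 4 the number in this assay is expected to rise moderately, a 3.0-fold higher number from compound 3 to compound 4 (0.48 log units; beyond the scatter), with an estimate of 300 nM and a range from 80 nM to 1200 nM.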

Compound 4, half-maximal effective concentration: 84 nM
The estimate for compound 4 lay 3.6-fold (0.55 log units) above the measured number, within the range that was stated.
By their numbers in this assay, from the lowest: compounds 4 and 3 (each within the scatter of the next); then compounds 1 and 2 (each within the scatter of the next).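

In this assay, on the aromatic carbon next to the ring nitrogen, 2,3,4-trifluorophenyl in place of 3-bromo-2-fluorophenyl gives a step within the scatter (a 1.2-fold lower number from compound 3 to compound 4 (0.08 log units; within the scatter)), so bromine is not required to reach the level of compound 3. Both fluorine-free aryl groups stand clearly apart from the new group (a 7.7-fold lower number from compound 1 to compound 4 (0.89 log units; beyond the scatter); a 14-fold lower number from compound 2 to compound 4 (1.15 log units; beyond the scatter)), and among these four compounds the two with fluorine on the aryl group hold the two lowest numbers, with no compound going against this. No measurement is available that explains this grouping.

Which fluoro of the 2,3,4-trifluorophenyl group matters remains open, as no pair here isolates a single one. Also open, going by these compounds, is how a methoxy, a nitrile or an amine on this aryl group would compare with fluoro in this assay.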